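Swapping One Aryl Substituent for Another: Clearance Expectation

The source may report more compounds than this note shows. Statements on the series, on what has been measured and on what is new or still open speak of the compounds shown alone.

Compound 1 `Nc1ccc(S(=O)(=O)N2CCN(c3ncc(C(O)(C(F)(F)F)C(F)(F)F)cc3Br)CC2)cn1`: 32 mL.min-1.g-1
Compound 2 `Nc1ccc(S(=O)(=O)N2CCN(c3ncc(C(O)(C(F)(F)F)C(F)(F)F)cc3C#CC3CC3)CC2)cn1`: 67 mL.min-1.g-1
Compound 3 `CS(=O)(=O)Nc1cccc(-c2cc(C(O)(C(F)(F)F)C(F)(F)F)cnc2N2CCN(S(=O)(=O)c3ccc(N)nc3)CC2)c1`: 81 mL.min-1.g-1

In an ADME assay (liver) for metabolic stability, with Liver microsome (Rattus norvegicus) as the target, using microsomes and NADPH, with a stated time of 30 min, tested at 1 uM (on this read-out higher numbers stand for fast clearance and lower numbers for slow clearance), compound 3 gives the highest of the three numbers. Its nearest neighbour is compound 2: the step of a 1.2-fold higher number from compound 2 to compound 3 (0.08 log units; within the scatter) lies within the scatter, so the two cannot be ranked against each other. Compound 1 sits furthest away, with the step of a 2.5-fold higher number from compound 1 to compound 3 (0.40 log units; beyond the scatter), and the step of a 2.1-fold higher number from compound 1 to compound 2 (0.32 log units; beyond the scatter) is of similar size.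

Compound 4 `Nc1ccc(S(=O)(=O)N2CCN(c3ncc(C(O)(C(F)(F)F)C(F)(F)F)cc3-c3ccc4scnc4c3)CC2)cn1` is not yet measured. The change from compound 3 is 1,3-benzothiazol-5-yl in place of 3-(methanesulfonamido)phenyl on an aromatic carbon.

Which measured steps bear on this? Going by the values given here, the two steps that run beyond the scatter, a 2.1-fold higher number from compound 1 to compound 2 (0.32 log units; beyond the scatter) and a 2.5-fold higher number from compound 1 to compound 3 (0.40 log units; beyond the scatter), both replace bromo with a large group; the one step that swaps one large group for another, a 1.2-fold higher number from compound 2 to compound 3 (0.08 log units; within the scatter), stays within the scatter. The change to compound 4 is again a swap of one large group for another at the same aromatic carbon, so no step beyond the scatter is expected in this assay, in either direction.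

Compound 4 is therefore expected to give about 75 mL.min-1.g-1, within the range 40 mL.min-1.g-1 to 150 mL.min-1.g-1, which amounts to the expected step of a 1.1-fold lower number from compound 3 to compound 4 (0.03 log units; within the scatter).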

Compound 4, intrinsic clearance in microsomes: 147 mL.min-1.g-1
Compound 4: the middle estimate sits 2.0-fold (0.29 log units) below what was measured; measured number inside the range.
By their numbers in this assay, from the lowest: compound 1; then compounds 2, 3 and 4 (each within the scatter of the next, the first and the last beyond it).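

In this assay, replacing 3-(methanesulfonamido)phenyl with 1,3-benzothiazol-5-yl at this aromatic carbon again gives a swap of one large group for another that stays within the scatter, a 1.8-fold higher number from compound 3 to compound 4 (0.26 log units; within the scatter), even though the entering group brings a second aromatic ring and no hydrogen-bond donor. Going by these compounds alone, the substituents at this position are nevertheless not all interchangeable in this read-out: a 2.2-fold higher number from compound 2 to compound 4 (0.34 log units; beyond the scatter) is the first step between two large groups to run beyond the scatter, although compound 3 remains within the scatter of both compound 2 and compound 4. The bromo compound also stays apart from all three large groups, with a 4.6-fold higher number from compound 1 to compound 4 (0.66 log units; beyond the scatter) extending the separation already seen for compound 2 and compound 3.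

No measurement shown here accounts for any of these differences in clearance.

Going by these compounds, it remains open whether an unsubstituted phenyl, or a phenyl carrying an amine or a carboxylic acid in place of the methanesulfonamido group, would lie nearer compound 1 or compound 4 at this same carbon.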